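Triazole-linked bis-arylidene piperidinones: halogen swap on the benzyl

The compounds below may be only part of what the source reports. "The series", "measured", "known", "first", "only" and "open" are said of these compounds alone.

Compound 1 `Cc1ccc(/C=C2\CN(Cc3cn(Cc4ccc(F)cc4)nn3)C/C(=C\c3ccc(C)cc3)C2=O)cc1` and compound 2 `Cc1ccc(/C=C2\CN(C(=S)SCc3cn(Cc4ccc(F)cc4)nn3)C/C(=C\c3ccc(C)cc3)C2=O)cc1` share the bis-arylidene piperidinone core; the difference between the two cores is not broken down here. In a functional assay on PC-3 cells (Homo sapiens) for cytotoxicity, read by MTT assay, with a stated time of 24 h (a higher number here means a weaker inhibitor, a lower number a stronger inhibitor), compound 1 gives 65600 nM and compound 2 gives 45500 nM. Compound 3 `Cc1ccc(/C=C2\CN(C(=S)SCc3cn(Cc4cccc(Cl)c4)nn3)C/C(=C\c3ccc(C)cc3)C2=O)cc1` carries the change 3-chlorophenyl in place of 4-fluorophenyl on a saturated chain carbon bound to an aromatic nitrogen relative to compound 2. In this assay compound 3 reaches only a limit, > 80000 nM, not a number. That step, an at least 1.7-fold higher number from compound 2 to compound 3 (0.24 log units; that floor lies within the scatter), is bounded by the limit (the limit of > 80000 nM in this assay, at which 1 of the 3 values shown sits). Compound 4 `Cc1ccc(/C=C2\CN(Cc3cn(Cc4cccc(Cl)c4)nn3)C/C(=C\c3ccc(C)cc3)C2=O)cc1` is the same change made on compound 1, (3-chlorophenyl in place of 4-fluorophenyl on a saturated chain carbon bound to an aromatic nitrogen), at the same place. The expectation for compound 4 in this assay is a step of a 1.7-fold higher number from compound 1 to compound 4 (0.22 log units; within the scatter), resting on compound 1 at 65600 nM and on the direction seen in an at least 1.7-fold higher number from compound 2 to compound 3 (0.24 log units; that floor lies within the scatter). That measured step is bounded by the limit of > 80000 nM in this assay, at which 1 of the 3 values shown sits, which leaves the expected number for compound 4 uncertain. The estimate for compound 4 is 110000 nM, between 55000 nM and 250000 nM.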

Compound 4, half-maximal inhibitory concentration: 29300 nM
For compound 4 the middle estimate is 3.8-fold (0.57 log units) above the measured one, and the stated range ends above it.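

In this assay, the change from 4-fluorobenzyl to 3-chlorobenzyl gives a 2.2-fold lower number from compound 1 to compound 4 (0.35 log units; beyond the scatter), so the effect of this change does not carry from one core to the other in this pair of cores: the same change on two cores in this assay, an at least 1.7-fold higher number (0.24 log units; that floor lies within the scatter) from compound 2 to compound 3 and a 2.2-fold lower number (0.35 log units; beyond the scatter) from compound 1 to compound 4, at least 3.9-fold (0.59 log units) apart, beyond the scatter of two such steps. Compound 3 stands at a limit, not a number, so the step to it has a floor but no measured size: the limit of > 80000 nM in this assay, at which 1 of the 4 values shown sits. The result shows that the outcome of the change depends on the core here, but it does not show which difference between the cores is responsible.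

The change alters both the halogen and its place on the ring, and the compounds shown do not separate the two. From the compounds shown here alone, it also remains open how either core responds to a benzyl carrying a methoxy group or a nitrile.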